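This account rests on a few compounds, and the source may have more. Where it says the series, first, only, none or still open, it means among the compounds named here.

Compound 2 `FC(F)(F)c1ccc(CSc2nc(Nc3cccc(C(F)(F)F)c3)c3ccccc3n2)cc1` gives 11100 nM in a functional assay on MDA-MB-231 cells (Homo sapiens) for cytotoxicity, read by MTT assay, with a stated time of 72 h; on this read-out higher numbers stand for weaker inhibition and lower numbers for stronger inhibition; compound 1 `CCCCCCNc1nc(SCc2ccc(C(F)(F)F)cc2)nc2ccccc12`, which gives 20200 nM, lies within the scatter of it, as the step of a 1.8-fold lower number from compound 1 to compound 2 (0.26 log units; within the scatter) shows. Compound 3 `O=[N+]([O-])c1ccc(Nc2nc(SCc3ccc(C(F)(F)F)cc3)nc3ccccc23)cc1` differs from compound 2 by 4-nitrophenyl in place of 3-(trifluoromethyl)phenyl on a nitrogen on an aromatic ring. For the measured compounds named here, the only measured step exchanged hexyl for an aryl group; no measured step exchanges one aryl group for another, so nothing recorded bears directly on this change. Compound 3 is therefore expected to show no step beyond the scatter, a 1.0-fold lower number from compound 2 to compound 3 (0.00 log units; within the scatter). The estimate for compound 3 is 11000 nM, with a range from 4000 nM to 30000 nM.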

Compound 3, half-maximal inhibitory concentration: 8670 nM
Compound 3: the middle estimate sits 1.3-fold (0.10 log units) above what was measured, within the range that was stated.
By their numbers in this assay, from the lowest: compounds 3, 2 and 1 (each within the scatter of the next, the first and the last beyond it).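

In this assay the exchange of one aryl group for another on the nitrogen gives a 1.3-fold lower number from compound 2 to compound 3 (0.11 log units; within the scatter) and so does not separate 4-nitrophenyl from 3-(trifluoromethyl)phenyl. Set against hexyl, 4-nitrophenyl gives a 2.3-fold lower number from compound 1 to compound 3 (0.37 log units; beyond the scatter) and this is the only step at this position beyond the scatter, though a modest one. Nothing available here accounts for either step.

On these data alone, it remains open what a phenyl ring carrying an amine or a carboxylic acid, or a chain shorter than hexyl, would give on this nitrogen. As far as these compounds go, it is also open whether any group here could bring the number far lower.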